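Stereochemistry in a Small Ring: Compound 2 to Compound 3

The source may hold more compounds than are shown below. What is called first, only, known or untested is meant among the compounds shown, and "the series" means these compounds.

Two diastereomers of the same azetidine have been tested in a functional assay on L1210 cells (Mus musculus) for cytotoxicity; a higher number here means a weaker inhibitor, a lower number a stronger inhibitor. Compound 1 `CCCCCCCCCCCCCC[C@H]1N[C@H](CO)[C@H]1O` gives 4.5 ug/mL; compound 2 `CCCCCCCCCCCCCC[C@H]1N[C@@H](CO)[C@@H]1O` gives 1.6 ug/mL, the lowest of the two numbers, with compound 1 as its nearest neighbour. The step of a 2.8-fold lower number from compound 1 to compound 2 (0.45 log units; beyond the scatter) shows that swapping the drawn configuration at two ring carbons matters here, because the fact that compounds 1 and 2 differ only in the configuration as drawn is the only thing that separates the pair.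

Compound 3 `CCCCCCCCCCCCCC[C@@H]1N[C@H](CO)[C@@H]1O` is the next diastereomer. Its change from compound 2 is the two compounds have the same atoms and bonds and differ only in configuration as drawn: 2 of 3 stereo elements differ; a stereocentre at a saturated ring carbon is drawn R in compound 2 and S in compound 3; a stereocentre at a saturated ring carbon is drawn S in compound 2 and R in compound 3. Going by the values given here, the only comparable step, from compound 1 to compound 2, was of modest size, so a step of similar size in either direction is expected, most likely back toward a somewhat higher number. For compound 3 the expected step is a 1.9-fold higher number from compound 2 to compound 3 (0.27 log units; within the scatter), giving an estimate of 3 ug/mL, with a likely range from 1 ug/mL to 9 ug/mL.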

Compound 3, half-maximal inhibitory concentration: 7.5 ug/mL
The estimate for compound 3 lay 2.5-fold (0.40 log units) below the measured number; the measured number falls inside the stated range.
By their numbers in this assay, from the lowest: compound 2; then compounds 1 and 3 (each within the scatter of the next).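

In this assay, the step of a 4.7-fold higher number from compound 2 to compound 3 (0.67 log units; beyond the scatter) shows that the low number of compound 2 does not carry over to compound 3, and this can be traced to stereochemistry alone because nothing else separates the pair: the fact that compounds 2 and 3 differ only in the configuration as drawn. Yet a change at two ring stereocentres does not always move the number, as compounds 1 and 3 show with a 1.7-fold higher number from compound 1 to compound 3 (0.22 log units; within the scatter). Among these three diastereomers, only compound 2 stands apart from both others by more than the scatter.

Every step here changes two stereocentres at once, so the effect of inverting any single centre cannot be read. From the compounds shown here alone, it also remains open whether compound 2 would keep its place with a shorter chain or with an amine added to the shared core.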